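The source may report more compounds than this note shows. Statements on the series, on what has been measured and on what is new or still open speak of the compounds shown alone.

Three compounds share one core and differ only in the group that hangs from a saturated chain carbon bound to an aromatic nitrogen. Compound 1 `CCCCn1cc(Cn2nc(N)c3c(C(F)(F)F)cc(-c4ccccc4)nc32)nn1` carries a propyl there, and in a functional assay on THP-1 cells (Homo sapiens) for cytotoxicity, read by MTT assay, with a stated time of 24 h (a lower number here means a stronger inhibitor, a higher number a weaker inhibitor), compound 1 gives 46.1 ug/mL. Compound 2 `COc1ccc(NC(=O)Cn2cc(Cn3nc(N)c4c(C(F)(F)F)cc(-c5ccccc5)nc43)nn2)cc1` carries a (4-methoxyphenyl)carbamoyl instead, and in this assay compound 2 gives 56.7 ug/mL. Compound 3 `Nc1nn(Cc2cn(CC(=O)Nc3cccc(F)c3)nn2)c2nc(-c3ccccc3)cc(C(F)(F)F)c12` carries a (3-fluorophenyl)carbamoyl, and in this assay compound 3 gives 99.5 ug/mL. Compound 3 thus sits apart from compound 1 by a 2.2-fold higher number from compound 1 to compound 3 (0.33 log units; beyond the scatter), while its separation from compound 2, a 1.8-fold higher number from compound 2 to compound 3 (0.24 log units; within the scatter), stays inside the scatter. Compound 4 `Nc1nn(Cc2cn(CC(=O)Nc3ccccc3Br)nn2)c2nc(-c3ccccc3)cc(C(F)(F)F)c12` is the next variation: 2-bromophenyl in place of 3-fluorophenyl on an amide-type nitrogen. For the measured compounds named here, the only measured step that bears on this kind of change is the swap of one aryl for another on the amide-type nitrogen, a 1.8-fold higher number from compound 2 to compound 3 (0.24 log units; within the scatter), which was small. A similarly small step, or none beyond the scatter, is therefore expected here, a 1.1-fold lower number from compound 3 to compound 4 (0.04 log units; within the scatter). On that basis compound 4 is estimated at 90 ug/mL, with a range from 45 ug/mL to 180 ug/mL.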

Compound 4, half-maximal inhibitory concentration: 95.3 ug/mL
Estimate against measurement, compound 4: 1.1-fold (0.02 log units) below; low and high end bracket the measured number.
By their numbers in this assay, from the lowest: compounds 1, 2, 4 and 3 (each within the scatter of the next, the first and the last beyond it).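

The swap from 3-fluorophenyl to 2-bromophenyl on the amide-type nitrogen barely registers in this assay (a 1.0-fold lower number from compound 3 to compound 4 (0.02 log units; within the scatter)), and the swap from 4-methoxyphenyl is also small (a 1.7-fold higher number from compound 2 to compound 4 (0.23 log units; within the scatter)), so three differently substituted phenyl rings at this position now read alike. Replacing propyl with (2-bromophenyl)carbamoyl gives a modest step (a 2.1-fold higher number from compound 1 to compound 4 (0.32 log units; beyond the scatter)), a second case beyond the scatter, although compound 2 goes against any general rule for these carbamoyl groups (a 1.2-fold higher number from compound 1 to compound 2 (0.09 log units; within the scatter)). No measured evidence is available to explain these small differences.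

From the compounds shown here alone, it remains open whether an amine or a carboxylic acid on the phenyl ring would shift the number beyond the scatter. A longer chain in place of propyl is equally unexplored in the compounds shown.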